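Carbamate in place of oxan-4-yl amide on a pyrazole

The source may report more compounds than this note shows. Statements on the series, on what has been measured and on what is new or still open speak of the compounds shown alone.

Measured compounds:
compound 1, `Cc1cc(NC(=O)C(C)C)nn1Cc1cc(Cl)ccc1OCc1ccccc1` — > 3.7
compound 2, `Cc1cc(NC(=O)C2CCOCC2)nn1Cc1cc(Cl)ccc1OCc1ccccc1` — > 3.7

In a physicochemical assay for lipophilicity, at pH 7.4 (on this read-out higher numbers stand for higher lipophilicity and lower numbers for lower lipophilicity), compound 1 gives > 3.7, which is a limit of the assay rather than a number. Compound 2 likewise gives > 3.7 in this assay, again a limit and not a number. The step that the two limits leave unreadable from compound 1 to compound 2 therefore cannot be read. What the data show is the limit of > 3.7 in this assay, at which 2 of the 2 values shown sit, so compound 2 stands at the upper edge of what this assay reports, with no value inside the measurable range beside it.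

Compound 3, `CCOC(=O)Nc1cc(C)n(Cc2cc(Cl)ccc2OCc2ccccc2)n1`, differs from compound 2 by ethoxy in place of oxan-4-yl on a carbonyl carbon. No measured step bears on this change: the one step shown, from compound 1 to compound 2, is unreadable in size because both of its ends sit at the limit. The estimate for compound 3 can rest only on the limit of compound 2 and on the exchange of oxan-4-yl for ethoxy. Compound 3 is therefore expected to sit near or at the same limit, with a step that the limit leaves unreadable from compound 2 to compound 3 estimated, and a value of about 4 expected, within the range 3.5 to 4.6.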

Compound 3, distribution coefficient: > 3.7
Compound 3 was reported as a limit; the forecaster's own chance of this, stated with the estimate: 70%; the middle value lies beyond the limit too.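

No new step can be read among compound 1, compound 2 and compound 3 in this assay, and the evidence is a single limit shared by all three: the limit of > 3.7 in this assay, at which 3 of the 3 values shown sit.

The compounds shown leave open how far the isopropyl, oxan-4-yl and ethoxy versions differ in this assay, or whether they differ at all.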